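Five-membered heteroaryl swap on the shared core

The source may report more compounds than this note shows. Statements on the series, on what has been measured and on what is new or still open speak of the compounds shown alone.

compound 1 `COc1ccc([C@@H]2C(c3ccoc3)C(=O)N2c2cc(OC)c(OC)c(OC)c2)cc1`: 150 nM
compound 2 `COc1cc(N2C(=O)[C@H](c3cccs3)[C@H]2c2cccc3ccccc23)cc(OC)c1OC`: 620 nM
compound 3 `COc1ccc([C@@H]2[C@@H](C(O)c3ccoc3)C(=O)N2c2cc(OC)c(OC)c(OC)c2)cc1`: 1100 nM

In a functional assay on MCF7 cells (Homo sapiens) for antiproliferative activity, read by MTT assay (a higher number here means a weaker inhibitor, a lower number a stronger inhibitor), compound 1 gives 150 nM, the lowest of the three numbers. Compound 2 gives 620 nM and compound 3 gives 1100 nM, both beyond the scatter from compound 1. For the measured compounds named here, neither differs from compound 1 in one place only, so no single-change step is available among the measured compounds.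

Compound 4 `COc1ccc([C@@H]2C(c3cccs3)C(=O)N2c2cc(OC)c(OC)c(OC)c2)cc1` differs from compound 1 by thiophen-2-yl in place of furan-3-yl on a saturated ring carbon. Compound 2 also carries a thiophen-2-yl group on the core, but its other changes leave the effect of this swap alone unresolved. A small step is expected, within the scatter or a modest weakening, estimated as a 1.7-fold higher number from compound 1 to compound 4 (0.22 log units; within the scatter). Compound 4 is expected to give 250 nM, with a range of 80 nM to 800 nM.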

Compound 4, half-maximal inhibitory concentration: 64 nM
The estimate for compound 4 lay 3.9-fold (0.59 log units) above the measured number; the whole stated range lies above it.
By their numbers in this assay, from the lowest: compound 4; then compound 1; then compounds 2 and 3 (each within the scatter of the next).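

Thiophen-2-yl in place of furan-3-yl on this saturated ring carbon gives, in this assay, a 2.3-fold lower number from compound 1 to compound 4 (0.37 log units; beyond the scatter), a modest gain beyond the scatter. For the compounds shown here, this is the first single-change step at this position, and it shows that the position accepts one five-membered aromatic ring in place of another without loss. No measured property bearing on this step is available.

Open, going by these compounds, is how furan-2-yl or thiophen-3-yl would read on this carbon, so the ring hetero atom and the point of attachment remain unseparated. Also open, on these data alone, is whether a phenyl ring or an aminomethyl group would be accepted here.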